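Two sulfur-linked pairs and an expected shift

The source may hold more compounds than are shown below. What is called first, only, known or untested is meant among the compounds shown, and "the series" means these compounds.

Compound 1 `CC(O)(CSc1ccccc1C(F)(F)F)C(=O)Nc1cc(C(F)(F)F)cc(C(F)(F)F)c1` is the starting point of this small set. In a functional assay on VCaP cells (Homo sapiens) for antiproliferative activity, read by fluorescence and propidium iodide staining, with a stated time of 96 h (a lower number here means a stronger inhibitor, a higher number a weaker inhibitor), compound 1 gives 3840 nM. Compound 2 `CC(O)(CSc1cccc(OC(F)(F)F)c1)C(=O)Nc1cc(C(F)(F)F)cc(C(F)(F)F)c1` differs from it by one change, (3-(trifluoromethoxy)phenyl in place of 2-(trifluoromethyl)phenyl on a sulfur), and in this assay compound 2 gives 9290 nM. That change produced a 2.4-fold higher number from compound 1 to compound 2 (0.38 log units; beyond the scatter).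

Compound 3 `CC(O)(CS(=O)(=O)c1ccccc1C(F)(F)F)C(=O)Nc1cc(C(F)(F)F)cc(C(F)(F)F)c1` carries a different core; how the core of compound 3 differs from the core of compound 1 is not broken down here. In this assay compound 3 gives 8550 nM. Compound 4 `CC(O)(CS(=O)(=O)c1cccc(OC(F)(F)F)c1)C(=O)Nc1cc(C(F)(F)F)cc(C(F)(F)F)c1` is not yet measured. It relates to compound 3 by 3-(trifluoromethoxy)phenyl in place of 2-(trifluoromethyl)phenyl on a sulfonyl sulfur. Among the measured compounds shown here, this is the same kind of change as the one from compound 1 to compound 2, but not the same: there the group sits on a sulfur whose other neighbour is a saturated chain carbon, here on a sulfonyl sulfur whose other neighbour is a saturated chain carbon.

Resting on the single measured example of this change, compound 1 to compound 2, the step from compound 3 to compound 4 in this assay is expected to be a 2.1-fold higher number from compound 3 to compound 4 (0.32 log units; beyond the scatter), a shift of similar size and direction. Compound 4 is therefore estimated at 18000 nM, with a likely range from 8000 nM to 45000 nM.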

Compound 4, half-maximal inhibitory concentration: 9990 nM
Estimate against measurement, compound 4: 1.8-fold (0.26 log units) above, and the stated range covers the measured number.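

In this assay, 3-(trifluoromethoxy)phenyl in place of 2-(trifluoromethyl)phenyl on a sulfonyl sulfur gives a 1.2-fold higher number from compound 3 to compound 4 (0.07 log units; within the scatter), so on this core the step stays within the scatter. Set beside the earlier step, the two results cannot be told apart: the same change on two cores in this assay, a 2.4-fold higher number (0.38 log units; beyond the scatter) from compound 1 to compound 2 and a 1.2-fold higher number (0.07 log units; within the scatter) from compound 3 to compound 4, 2.1-fold (0.32 log units) apart, within the scatter of two such steps. This shows that the steps on the core of compound 1 and the core of compound 3 are compatible with each other, but with a single pair on each core it does not show that they are equal, nor that the change would have the same effect on any other core in this series.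

The compounds shown leave open how other groups on the phenyl ring, such as a nitrile or a chlorine atom, would compare with trifluoromethyl and trifluoromethoxy. They also leave open what an amine in place of the hydroxyl group, or a longer chain in place of the methyl group, would do in this assay.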